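A few compounds are considered here, and "the series" means these few. Any claim that something is new, unique, unknown or untested is made for them only; others in the source may bear on it.

Working notes on the series. Two compounds have numbers in an assay on the whole organism (plasma, strain Sprague-Dawley) for inhibition of Dipeptidyl peptidase 4 (Rattus norvegicus), with a stated time of 6 h, at a dose of 1 mg/kg by the oral route; a lower number here means less inhibition, a higher number more inhibition at the dose given (going by the name of the read-out). Compound 1, `C[C@@H]1N[C@H](C(=O)N2CCC[C@H]2C#N)C[C@@H]1C(=O)N1CCC1`, gives 94%. Compound 2, `N#C[C@@H]1CCCN1C(=O)[C@@H]1C[C@H](C(=O)N2CCCCC2)CN1`, gives 84%, which stands within the scatter of the number for compound 1; the two are not separated by these data. Compound 3, `C[C@@H]1N[C@H](C(=O)N2CCC[C@H]2C#N)C[C@@H]1C(=O)N1CCCCC1`, has not been measured. It differs from compound 2 by methyl in place of hydrogen on a saturated ring carbon. Among the compounds with values here, no measured pair isolates this change, so the step from compound 2 to compound 3 in this assay is expected to be small, in either direction or none beyond the scatter, estimated as a number 4 percentage points higher from compound 2 to compound 3 (within the scatter). Compound 3 is estimated to give 88%, with a range from 74% to 97%.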

Compound 3, a percentage reported as inhibition, in the whole organism at one dose (the size of the read-out at that dose, not a potency): 91%
Beside the measured number, compound 3's estimate is 3 percentage points below it, and the stated range covers the measured number.
By their numbers in this assay, from the lowest: compounds 2, 3 and 1 (each within the scatter of the next).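

In this assay, methyl in place of hydrogen on a saturated ring carbon next to the ring nitrogen gives a number 7 percentage points higher from compound 2 to compound 3 (within the scatter) and so leaves the read-out within the scatter at this position. With that methyl in place, piperidin-1-yl in place of azetidin-1-yl on a carbonyl carbon gives a number 3 percentage points lower from compound 1 to compound 3 (within the scatter) and also stays within the scatter. No measurement on hand bears on the reason for either step. Open, from the compounds shown here alone, is how this ring carbon responds to a longer chain such as ethyl, or to an amine or hydroxyl group. A single dose and time also leave any difference in potency unread.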